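Core series: one chloro removed from compound 2

A few compounds are considered here, and "the series" means these few. Any claim that something is new, unique, unknown or untested is made for them only; others in the source may bear on it.

Compound 2 `NC1=NC2(CCOCC2)N(OCCCOc2cccc(Cl)c2Cl)C(N)=N1` gives 330 nM in a functional assay on HepG2 cells (Homo sapiens) for antiproliferative activity, read by MTT assay, with a stated time of 72 h (on this read-out higher numbers stand for weaker inhibition and lower numbers for stronger inhibition), the highest number of the three measured. Compound 1 `NC1=NC2(CCSCC2)N(OCCCOc2ccc(Cl)c(Cl)c2)C(N)=N1` gives 70 nM and compound 3 `NC1=NC2(CCSCC2)N(OCCCOc2ccccc2Br)C(N)=N1` gives 90 nM in this assay. Among the measured compounds shown here, the only step between measured compounds, a 1.3-fold higher number from compound 1 to compound 3 (0.11 log units; within the scatter), exchanges the whole aryl group on the core of compound 1 and stays within the scatter, so it offers no guide to a hydrogen in place of chloro on the core of compound 2. Compound 4 `NC1=NC2(CCOCC2)N(OCCCOc2cccc(Cl)c2)C(N)=N1` differs from compound 2 by hydrogen in place of chloro on an aromatic carbon. For the measured compounds named here, with no measured step bearing on this change, compound 4 is expected to stay close to compound 2, a 1.2-fold higher number from compound 2 to compound 4 (0.08 log units; within the scatter), with the range leaving room for a modest loss. The estimate for compound 4 is 400 nM, between 150 nM and 1200 nM.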

Compound 4, half-maximal inhibitory concentration: 150 nM
Estimate against measurement, compound 4: 2.7-fold (0.43 log units) above; the measured number falls inside the stated range.
By their numbers in this assay, from the lowest: compounds 1, 3 and 4 (each within the scatter of the next, the first and the last beyond it); then compound 2.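

In this assay, 2,3-dichlorophenyl to 3-chlorophenyl gives a 2.2-fold lower number from compound 2 to compound 4 (0.34 log units; beyond the scatter), so on the core of compound 2 this chloro, ortho to a chloro group, is not required for activity, and losing it lowers the number modestly. Unlike the earlier aryl exchange, this is a change at a single place, and its step lies beyond the scatter. No measured evidence accounts for this step.

Still open, on these data alone, is whether fluoro, methyl or methoxy at this place would lower the number further. Also open, as far as these compounds go, is whether the same change gives a similar step on the core of compound 1.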